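Lengthening a Side Chain on a Leukotriene Receptor Ligand

The source may report more compounds than this note shows. Statements on the series, on what has been measured and on what is new or still open speak of the compounds shown alone.

Compound 1, `CC(=O)c1cc(C)c(OCCCCC#N)cc1O`: 79%
Compound 2, `CCCCc1cc(C(C)=O)c(O)cc1OCCCCC#N`: 41%

Both measured compounds were tested in an assay on isolated protein for inhibition of leukotriene B4 receptor 1 (Homo sapiens), tested at 10 uM; on this read-out higher numbers stand for more inhibition at the one concentration tested (going by the name of the read-out) and lower numbers for less inhibition. In this assay compound 1 gives 79%, while compound 2 gives 41%. Compound 2 thus stands lowest of the two numbers. Among the measured compounds shown here, the one measured step joining them is a number 38 percentage points lower from compound 1 to compound 2 (beyond the scatter); that single change, a propyl in place of hydrogen on a saturated chain carbon bound to an aromatic carbon, carried a large loss of inhibition.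

Compound 3, `CCCCCc1cc(C(C)=O)c(O)cc1OCCCCC#N`, is not yet measured. It differs from compound 2 in one place: methyl in place of hydrogen on a saturated chain carbon, four bonds along the chain from an aromatic carbon. For the measured compounds named here, this is the same chain grown once more, so the step from compound 1 to compound 2 is the only guide. Because that step was a number 38 percentage points lower from compound 1 to compound 2 (beyond the scatter), a further lowering is expected, though a single added carbon should move the number less than three did. Compound 3 is therefore expected to give 30%, with a likely range of 10% to 50%. This estimate corresponds to an expected step of a number 11 percentage points lower from compound 2 to compound 3 (beyond the scatter).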

Compound 3, a percentage reported as inhibition, at one concentration (the size of the read-out at that concentration, not a potency): 31%
Compound 3: the middle estimate sits 1 percentage points below what was measured; low and high end bracket the measured number.
By their numbers in this assay, from the lowest: compounds 3 and 2 (each within the scatter of the next); then compound 1.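

Methyl in place of hydrogen on a saturated chain carbon, four bonds along the chain from an aromatic carbon, gives a number 10 percentage points lower from compound 2 to compound 3 (within the scatter) in this assay and so has no effect that can be told apart from ordinary variation between repeats. Set against compound 1, however, the longer chain in compound 3 still matters: the numbers give a number 48 percentage points lower from compound 1 to compound 3 (beyond the scatter) and show that the large loss first seen with propyl remains when the chain is grown by one more carbon. Why inhibition is lost at this position, and why this last carbon adds no readable change, cannot be said from the information available.

A longer chain could show whether the numbers stay in this range or keep falling, and a chain ending in an amine or a carboxylic acid could show whether a different end group brings any inhibition back. From the compounds shown here alone, with one tested concentration for each compound, how these compounds compare in potency also stays open.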